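Methylamino for methylsulfanyl in compound 2

The compounds below may be only part of what the source reports. "The series", "measured", "known", "first", "only" and "open" are said of these compounds alone.

Compound 1 `CSc1ncnc2c1c(-c1ccsc1)cn2[C@@H]1O[C@H](CO)[C@@H](O)[C@H]1O`: > 20000 nM, a limit
Compound 2 `CSc1ncnc2c1c(-c1ccccc1)cn2[C@@H]1O[C@H](CO)[C@@H](O)[C@H]1O`: > 20000 nM, a limit
Compound 3 `C#Cc1cn([C@@H]2O[C@H](CO)[C@@H](O)[C@H]2O)c2ncnc(SC)c12`: 140 nM

All three compounds were tested in a functional assay on A549 cells (Homo sapiens), read by MTT assay, with a stated time of 72 h; on this read-out higher numbers stand for weaker inhibition and lower numbers for stronger inhibition. Compound 2 gives only a limit, not a number, and stands at the limit of > 20000 nM in this assay, at which 2 of the 3 values shown sit.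

Compound 4 `CNc1ncnc2c1c(-c1ccccc1)cn2[C@@H]1O[C@H](CO)[C@@H](O)[C@H]1O` keeps the phenyl of compound 2 but carries methylamino in place of methylsulfanyl on an aromatic carbon, (methylamino in place of methylsulfanyl on an aromatic carbon).

Among the compounds with values here, no measured step changes this group, since all three compounds carry methylsulfanyl. The measured steps change the other group instead. There is an at least 140-fold lower number from compound 2 to compound 3 (2.15 log units; beyond the scatter), which is large, and an at least 140-fold lower number from compound 1 to compound 3 (2.15 log units; beyond the scatter), also large, while a step that the two limits leave unreadable from compound 1 to compound 2 cannot be sized. Both large steps bring in the ethynyl group, and compound 4 does not have it. Its closest measured relative remains compound 2, so a large drop is not expected, only a modest move towards lower numbers or none that can be read. The expected change is an at least 2.0-fold lower number from compound 2 to compound 4 (0.30 log units; that floor lies within the scatter). Compound 4 is estimated at 10000 nM, with an expected range of 2000 nM to 20000 nM.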

Compound 4, half-maximal inhibitory concentration: > 20000 nM
Compound 4 ended at the assay's limit; the forecaster's own chance of this, stated with the estimate: 60%; middle value at least 2.0-fold (0.30 log units) from the limit.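

In this assay compound 4 gives > 20000 nM, which is a limit and not a number. Compound 2 also stands at a limit, so the step between compound 2 and compound 4 cannot be read. The compounds shown leave open whether methylamino in place of methylsulfanyl changes inhibition at all.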